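Tert-Butyl for Methyl: Expecting a Small Step in Mice

A few compounds are considered here, and "the series" means these few. Any claim that something is new, unique, unknown or untested is made for them only; others in the source may bear on it.

Compound 1 `CCN1CCc2c(c(C)nn2C(=O)Nc2cc(C)ccc2C)C1` gives 2.6%
Compound 2 `CCN1CCc2c(c(C)nn2C(=O)Nc2cccc(C(F)(F)F)c2)C1` gives 4.4%
Compound 3 `CCN1CCc2c(c(C(C)(C)C)nn2C(=O)Nc2cc(C)ccc2C)C1` gives 0%

Of the compounds shown here, three with a shared core have been tested in a functional assay on the whole organism (strain Swiss albino) for inhibition, with Mus musculus as the target, in the formalin test, with stated times of 30 min and 5 min, at a dose of 100 mg/kg; a lower number here means less inhibition, a higher number more inhibition at the dose given (going by the name of the read-out). Compound 1 gives 2.6%, compound 2 gives 4.4% and compound 3 gives 0%. All three numbers lie within the usual scatter of one another, so none of them can be called stronger or weaker than the rest; each shows only a small inhibition at the dose given.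

Compound 1 and compound 3 differ in one place: tert-butyl in place of methyl on an aromatic carbon. That change gave a number 2.6 percentage points lower from compound 1 to compound 3 (within the scatter). The difference between the core of compound 1 and the core of compound 2 is not broken down here.

Compound 4 `CCN1CCc2c(c(C(C)(C)C)nn2C(=O)Nc2cccc(C(F)(F)F)c2)C1` has not yet been measured in this assay. It stands to compound 2 as compound 3 stands to compound 1: tert-butyl in place of methyl on an aromatic carbon. The place of the change is described in the same words in both pairs, so this is the same change. Because the earlier change gave a number 2.6 percentage points lower from compound 1 to compound 3 (within the scatter), a step of similar size is expected here, namely a number 2.4 percentage points lower from compound 2 to compound 4 (within the scatter), so the number for compound 4 is expected to stay level with that of compound 2. The estimate for compound 4 is 2%, expected to fall between 0% and 12%.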

Compound 4, a percentage reported as inhibition, in the whole organism at one dose (the size of the read-out at that dose, not a potency): 2.6%
Estimate against measurement, compound 4: 0.6 percentage points below; the measured number falls inside the stated range.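

In this assay, tert-butyl in place of methyl on an aromatic carbon of the core of compound 2 gave a number 1.8 percentage points lower from compound 2 to compound 4 (within the scatter). Set beside the earlier step, the same change looks alike on both cores, with no difference that can be told apart from ordinary variation between repeated measurements: the same change on two cores in this assay, a number 2.6 percentage points lower (within the scatter) from compound 1 to compound 3 and a number 1.8 percentage points lower (within the scatter) from compound 2 to compound 4, 0.8 percentage points apart, within the scatter of two such steps. This shows only that swapping methyl for tert-butyl made no readable difference on these two cores at this one dose; since both steps lie within the scatter and all four compounds show little inhibition, the agreement does not show that the change would carry over with the same size to a core where the inhibition is clearly larger, and it says nothing about cores beyond these two.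

The compounds shown leave open whether any other group on that aromatic carbon, such as an amine or a carboxylic acid, would move the inhibition clear of the scatter. They also leave open whether a nitrile in place of the trifluoromethyl group of compound 4 would do so, and how any of these compounds would behave at a different dose.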